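The source may report more compounds than this note shows. Statements on the series, on what has been measured and on what is new or still open speak of the compounds shown alone.

Compound 1 `COc1cc(-c2nn(-c3cccc(NC(=O)Nc4cc(C(F)(F)F)cc(C(F)(F)F)c4)c3)cc2-c2ccncc2)ccc1Cl`: 3980 nM
Compound 2 `COc1cc(-c2nn(-c3cccc(NC(=O)Nc4ccc(Cl)c(Cl)c4)c3)cc2-c2ccncc2)ccc1Cl`: 3610 nM
Compound 3 `O=C(Nc1cccc(-n2cc(-c3ccncc3)c(-c3ccc(Cl)c(O)c3)n2)c1)Nc1ccc(Cl)c(Cl)c1`: reported only as a limit, > 32500 nM

In a functional assay on OVCAR-8 cells (Homo sapiens) for inhibition, read by sulforhodamine B assay, with a stated time of 48 h (a lower number here means a stronger inhibitor of growth, a higher number a weaker inhibitor of growth), compound 1 gives 3980 nM, the highest of the two numbers shown, though compound 2 at 3610 nM sits within the scatter of it. Compound 3 gives only a limit in this assay, > 32500 nM. Among the measured compounds shown here, the single measured step, an at least 9.0-fold higher number from compound 2 to compound 3 (0.95 log units; beyond the scatter), concerns a methyl on an oxygen and does not bear on the change to compound 4 `COc1cc(-c2nn(-c3cccc(NC(=O)Nc4cccc(C(F)(F)F)c4)c3)cc2-c2ccncc2)ccc1Cl`, which is hydrogen in place of trifluoromethyl on an aromatic carbon. What compounds 1 and 2 do show is that two rather different substituent sets on the urea-bearing ring give values within the scatter of each other. A step within the scatter is therefore expected, and compound 4 is estimated at 5000 nM (range 2000 nM to 15000 nM), meaning a step of a 1.3-fold higher number from compound 1 to compound 4 (0.10 log units; within the scatter).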

Compound 4, concentration for total growth inhibition: 2700 nM
Beside the measured number, compound 4's estimate is 1.9-fold (0.27 log units) above it; the range from low to high includes it.
By their numbers in this assay, from the lowest: compounds 4, 2 and 1 (each within the scatter of the next). At a limit, above all of these: compound 3.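

In this assay, hydrogen in place of trifluoromethyl on this aromatic carbon gives a 1.5-fold lower number from compound 1 to compound 4 (0.17 log units; within the scatter), so the value of compound 1 does not depend on this trifluoromethyl group. The other listed step, a 1.3-fold lower number from compound 2 to compound 4 (0.13 log units; within the scatter), shows that 3-(trifluoromethyl)phenyl and 3,4-dichlorophenyl on the amide-type nitrogen are not told apart here. Nothing measured here explains why this change leaves the value within the scatter. Going by these compounds, whether an amine or a carboxylic acid on this carbon would move the value beyond the scatter stays open. So does the effect of removing the remaining trifluoromethyl group from compound 4.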